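The compounds below may be only part of what the source reports. "The series", "measured", "known", "first", "only" and "open" are said of these compounds alone.

Series notes, inhibition at a single concentration.

Compound 1 `O=c1cc(Cn2ccnc2)c2ccc(OCc3cccc(C(F)(F)F)c3)cc2o1` gives 0% in an assay for inhibition of steroid 17-alpha-hydroxylase/17,20 lyase (Homo sapiens), read by HPLC, with a stated time of 5 min, tested at 2.5 uM, in the presence of a further agent that is not named here; a lower number here means less inhibition, a higher number more inhibition at the concentration tested (going by the name of the read-out). Compound 2 `O=c1cc(Cn2ccnc2)c2ccc(OCc3cccc(F)c3)cc2o1` gives 0% in this assay, and compound 3 `CC(C)Oc1ccc(COc2ccc3c(Cn4ccnc4)cc(=O)oc3c2)cc1` gives 2% in this assay. For the measured compounds named here, the one measured step, no change at the digits printed from compound 1 to compound 2 (within the scatter), stays within the scatter. Compound 2 thus stands level with compound 1, the two together at the bottom of the three numbers, while compound 3 lies within the scatter of both; nothing in the set separates from the rest.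

Compound 4 `COc1cccc(COc2ccc3c(Cn4ccnc4)cc(=O)oc3c2)c1` carries the change (methoxy in place of fluoro on an aromatic carbon), on an aromatic carbon of the six-membered carbon-only ring, meta to a large group. The step that bears on it is no change at the digits printed from compound 1 to compound 2 (within the scatter), a swap at the same aromatic carbon that produced no movement at all; compound 3, with an isopropoxy on the same ring at another place, likewise sits within the scatter of compound 2. No measured exchange of a small group for an alkoxy group on this ring has shifted the read-out beyond the scatter, so the step of a number 2 percentage points higher from compound 2 to compound 4 (within the scatter) is expected to be none beyond the scatter. Compound 4 is therefore estimated at 2%, with a range of 0% to 12%.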

Compound 4, a percentage reported as inhibition, at one concentration (the size of the read-out at that concentration, not a potency): 2%
For compound 4 middle estimate and measured number coincide at the digits printed; the measured number falls inside the stated range.
By their numbers in this assay, from the lowest: compounds 1, 2, 3 and 4 (each within the scatter of the next).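

At this aromatic carbon, methoxy in place of fluoro gives a number 2 percentage points higher from compound 2 to compound 4 (within the scatter), and methoxy in place of trifluoromethyl gives a number 2 percentage points higher from compound 1 to compound 4 (within the scatter). In this assay, for the compounds shown here, the position has now taken a group that brings in oxygen, and fluoro, trifluoromethyl and methoxy remain unseparated, whereas the earlier step at this carbon compared only two groups without oxygen. No supporting measurement is available to explain this flat result.

The compounds shown leave open whether any group at this carbon can move the read-out beyond the scatter. An amine, a carboxylic acid or a longer alkoxy chain here could test that, and compounds differing only in that group would show whether the flat reading extends beyond these three groups.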